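Chain variation in a positive allosteric modulator series

This account rests on a few compounds, and the source may have more. Where it says the series, first, only, none or still open, it means among the compounds named here.

Three compounds share a core and have been run in an assay on HEK293 cells for positive allosteric modulation of metabotropic glutamate receptor 3 (Rattus norvegicus), read by thallium flux, with a stated time of 2.5 min; a lower number here means that less compound is needed, a higher number that more compound is needed for the effect. Compound 1 `Cc1c(OCCCCOCOc2ccc(C(=O)O)cc2)ccc(C(=O)CC2CCCC2)c1O` gives 1910 nM in this assay, the highest of the three numbers. Compound 2 `COc1cc(C(=O)O)ccc1OCCCCOc1ccc(C(=O)CC(C)C)c(O)c1C` gives 614 nM, and compound 3 `COc1ccc(C(=O)O)cc1OCCCCOc1ccc(C(=O)C(C)C)c(O)c1C` gives 588 nM; both of these sit beyond the scatter from compound 1, while their own two values lie within the scatter of each other, so no order is read between them. Going by the values given here, no step between compounds differing in a single place is available here, so no measured step size can be quoted.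

Compound 4 `Cc1c(OCCCCOc2ccc(C(=O)O)c(Cl)c2)ccc(C(=O)CC2CCCC2)c1O` is the next compound in line for this assay. Its change from compound 1 is 4-carboxy-3-chlorophenyl in place of (4-carboxyphenoxy)methyl on an oxygen on a saturated carbon. Among the compounds with values here, compound 2 and compound 3 show that a carboxy-bearing aromatic ring joined to the chain oxygen without the intervening methylene is compatible with the lower numbers seen so far, though neither carries a chlorine, and no measured compound carries it either. For compound 4 a step downward of a 2.7-fold lower number from compound 1 to compound 4 (0.44 log units; beyond the scatter) is expected in this assay, landing near the numbers of compound 2 and compound 3 rather than at the level of compound 1. The estimate for compound 4 is 700 nM, with a range from 250 nM to 2000 nM.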

Compound 4, half-maximal effective concentration: 2250 nM
Compound 4: middle estimate off by 3.2-fold (0.51 log units), on the low side; measured number outside the range, above it.
By their numbers in this assay, from the lowest: compounds 3 and 2 (each within the scatter of the next); then compounds 1 and 4 (each within the scatter of the next).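

In this assay, going by these compounds alone, replacing (4-carboxyphenoxy)methyl with 4-carboxy-3-chlorophenyl gives a 1.2-fold higher number from compound 1 to compound 4 (0.07 log units; within the scatter), the only comparison in this set between compounds that differ in one place. At this position, with the rest of the core of compound 1 held fixed, the two groups cannot be told apart by this read-out, although they differ in heavy atom count, in hydrogen-bond acceptor count and in the presence of a chlorine. No measurement is available here that bears on why the two numbers agree.

The exchange alters the connection to the aromatic ring and introduces the chlorine in a single step, so the result does not show what either alteration does alone, and two opposing contributions cannot be separated from no contribution at all. Open questions are where 4-carboxyphenyl without the chlorine would fall at this position, and whether a fluorine or a methyl group in place of the chlorine, or a tetrazole in place of the carboxylic acid, would give a number beyond the scatter from compound 1.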